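The source may report more compounds than this note shows. Statements on the series, on what has been measured and on what is new or still open speak of the compounds shown alone.

Compound 3 `O=C(NC1COCC(=O)N(Cc2ccccc2)C1=O)OCc1ccccc1` gives the highest of the three numbers recorded in a functional assay on the whole organism (strain ICR) with Mus musculus as the target, with a stated time of 30 min (on this read-out higher numbers stand for an effect only at larger amounts of compound and lower numbers for an effect already at smaller amounts), at 64.1 mg/kg. Compound 1 `CN1C(=O)COCC(NC(=O)OCc2ccccc2)C1=O` gives 41 mg/kg in this assay, and compound 2 `C=CCN1C(=O)COCC(NC(=O)OCc2ccccc2)C1=O` gives 37.1 mg/kg. The step of a 1.6-fold higher number from compound 1 to compound 3 (0.19 log units; within the scatter) and the step of a 1.7-fold higher number from compound 2 to compound 3 (0.24 log units; within the scatter) both lie within the scatter, as does a 1.1-fold lower number from compound 1 to compound 2 (0.04 log units; within the scatter), so the three groups placed so far on the ring nitrogen have left this read-out essentially unmoved.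

Compound 4 `O=C(NC1COCC(=O)N(O)C1=O)OCc1ccccc1` differs from compound 3 by hydroxy in place of benzyl on an amide-type nitrogen in a ring. All three measured steps concern the group on the same amide-type nitrogen in a ring and therefore bear on this change, but none of them introduces a hydroxy, and all of them were small. A step beyond the scatter is thus not expected in either direction, though the range must stay wide because the hydroxy has no precedent among these compounds. Compound 4 is estimated at 50 mg/kg, with a range from 22 mg/kg to 115 mg/kg. The expected step of a 1.3-fold lower number from compound 3 to compound 4 (0.11 log units; within the scatter) is accordingly small.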

Compound 4, dose for half-maximal effect: 96.9 mg/kg
The estimate for compound 4 lay 1.9-fold (0.29 log units) below the measured number, within the range that was stated.
By their numbers in this assay, from the lowest: compounds 2, 1, 3 and 4 (each within the scatter of the next, the first and the last beyond it).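

In this assay, for the compounds shown here, hydroxy on the amide-type nitrogen in a ring is the first group at this position to stand beyond the scatter from another, though only modestly, with a 2.4-fold higher number from compound 1 to compound 4 (0.37 log units; beyond the scatter) when it replaces methyl and a 2.6-fold higher number from compound 2 to compound 4 (0.42 log units; beyond the scatter) when it replaces allyl. The position is therefore not wholly indifferent to its substituent, yet the change from the largest group shown stays within the scatter (a 1.5-fold higher number from compound 3 to compound 4 (0.18 log units; within the scatter)), so compound 4 cannot be separated from compound 3 despite the loss of the aromatic ring. Nothing available explains these differences.

The compounds shown leave open whether methoxy or an amine at this position would behave like hydroxy or like the carbon groups. They also leave open how a longer chain would read here, and whether the same steps would hold if the group on the ring atom that bears a large group were different.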